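The source may hold more compounds than are shown below. What is called first, only, known or untested is meant among the compounds shown, and "the series" means these compounds.

The compounds in this set share one core and differ only in the group carried on its oxygen. Compound 2 `CC(C)O[C@@H]1C=CC(=O)[C@@H](CO)O1` bears an isopropyl there, compound 3 `O=C1C=C[C@@H](OC2CCCCC2)O[C@@H]1CO` a cyclohexyl, and compound 1 `COCCOCCOCCO[C@@H]1C=CC(=O)[C@@H](CO)O1` a longer ether chain; for compound 1 the result in a functional assay on MCF7 cells (Homo sapiens) for inhibition, read by MTT assay, with a stated time of 72 h (on this read-out higher numbers stand for weaker inhibition and lower numbers for stronger inhibition), is recorded as "not determined" (no result reported). Of the two numbers available, compound 2 stands at the higher end: in this assay compound 2 gives 36000 nM, while compound 3 gives 11000 nM, a gap that lies beyond the usual scatter.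

Compound 4 `C=CCO[C@@H]1C=CC(=O)[C@@H](CO)O1` is not yet measured. It differs from compound 2 in one place, as allyl in place of isopropyl on an oxygen on a saturated carbon shows; the group that leaves and the group that enters are both of three carbons and carry no donor or acceptor. Within the data shown here, with only two measured neighbours to lean on, no clear direction can be drawn. The step of a 1.2-fold lower number from compound 2 to compound 4 (0.08 log units; within the scatter) is expected to stay inside the scatter, without a change that would count as real. Compound 4 is accordingly estimated at 30000 nM, within a range from 12000 nM to 75000 nM.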

Compound 4, half-maximal inhibitory concentration: 16300 nM
For compound 4 the middle estimate is 1.8-fold (0.26 log units) above the measured one; low and high end bracket the measured number.
By their numbers in this assay, from the lowest: compounds 3 and 4 (each within the scatter of the next); then compound 2.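

In this assay, allyl in place of isopropyl on this oxygen gives a 2.2-fold lower number from compound 2 to compound 4 (0.34 log units; beyond the scatter), so this position registers a change even when the group that enters has the same count of heavy atoms as the one that leaves. The step is modest, but it shows that the carbon count alone does not fix the read-out here, and that the two groups differ in the allyl double bond and in the branching of the isopropyl. The data offer no measurement that explains the step.

The compounds shown leave open how a straight propyl group would read, which would separate the double bond from the branching. They also leave open how a benzyl group or a chain ending in an amine would read on this oxygen.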